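The compounds below may be only part of what the source reports. "The series", "measured", "known", "first", "only" and "open" are said of these compounds alone.

Measured compounds in a functional assay on HCT-116 cells (Homo sapiens) for inhibition, read by MTT assay, with a stated time of 48 h; a higher number here means a weaker inhibitor, a lower number a stronger inhibitor:

Compound 1 `O=C(CSc1nnc(-c2ccncc2)n1-c1ccccc1)N/N=C/c1ccc(O)cc1`: in this assay compound 1 gives > 50000 nM, which is a limit of the assay and not a number.
Compound 2 `O=C(CSc1nnc(-c2ccncc2)n1-c1ccccc1)N/N=C/c1ccc(Cl)cc1`: in this assay compound 2 gives 5740 nM.
Compound 3 `O=C(CSc1nnc(-c2ccncc2)n1-c1ccccc1)N/N=C/c1cccc(F)c1`: in this assay compound 3 gives > 50000 nM, again a limit of the assay and not a number.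

Compound 3 therefore stands at the weak end of what the three values show: it shares its limit with compound 1, as noted in the limit of > 50000 nM in this assay, at which 2 of the 3 values shown sit, and the step of an at least 8.7-fold higher number from compound 2 to compound 3 (0.94 log units; beyond the scatter) is the only readable one into it. The step that the two limits leave unreadable from compound 1 to compound 3 cannot be sized, since both ends sit at the limit.

Compound 4 `O=C(CSc1nnc(-c2ccncc2)n1-c1ccccc1)N/N=C/c1ccccc1O` differs from compound 3 by 2-hydroxyphenyl in place of 3-fluorophenyl on a carbon with a double bond to nitrogen. For the measured compounds named here, the steps that bear on this change are an at least 8.7-fold lower number from compound 1 to compound 2 (0.94 log units; beyond the scatter) and an at least 8.7-fold higher number from compound 2 to compound 3 (0.94 log units; beyond the scatter), both at least modest; a hydroxy-bearing ring and a fluorine-bearing ring each sit at the limit, and only the 4-chlorophenyl compound gives a number. Compound 4 carries a hydroxy-bearing ring, so compound 4 is expected to remain at or near the limit, an estimated 60000 nM with a range from 20000 nM to 200000 nM. The estimated step that the limit leaves unreadable from compound 3 to compound 4 is expected to stay within the scatter.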

Compound 4, half-maximal inhibitory concentration: 7060 nM
Compound 4: middle estimate off by 8.5-fold (0.93 log units), on the high side, and the stated range ends above it.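

In this assay, a hydroxy group on this ring does not by itself hold a compound at the limit: the 2-hydroxyphenyl of compound 4 gives a readable number, with an at least 7.0-fold lower number from compound 3 to compound 4 (0.85 log units; beyond the scatter) and an at least 7.0-fold lower number from compound 1 to compound 4 (0.85 log units; beyond the scatter). For the compounds shown here, the 4-chlorophenyl of compound 2 is also no longer the only group here to give a number, and a 1.2-fold higher number from compound 2 to compound 4 (0.09 log units; within the scatter) leaves compound 2 and compound 4 indistinguishable in this read-out. On the carbon with a double bond to nitrogen, the result therefore depends on the particular substituted phenyl group and not simply on whether it bears a hydroxy group, while the other two compounds remain at a limit of the assay, which is not a number: the limit of > 50000 nM in this assay, at which 2 of the 4 values shown sit.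

The compounds shown leave open whether a 2-aminophenyl or 2-methoxyphenyl group would also give a number in this assay, and whether a 2-chlorophenyl group would match compound 2 and compound 4. Going by these compounds, how far compound 1 and compound 3 truly lie from compound 4 also stays open, as does the effect of any change to the core of compound 1 outside this ring.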